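A few compounds are considered here, and "the series" means these few. Any claim that something is new, unique, unknown or untested is made for them only; others in the source may bear on it.

Measured compounds:
- compound 1, `Cc1cn([C@@H]2O[C@H](CO[Si](C)(C)C(C)(C)C)[C@@]3(OS(=O)(=O)C=C3NCC(=O)C(=O)N3CCC3)[C@H]2O[Si](C)(C)C(C)(C)C)c(=O)n(C)c1=O`, in a functional assay on HEL cells (Homo sapiens) for cytotoxicity, read by microscopy (a higher number here means that more compound is tolerated, a lower number that less compound is tolerated), gives 65000 nM
- compound 2, `C=C(C)C(=O)NC(=O)NC1=CS(=O)(=O)O[C@@]12[C@@H](CO[Si](C)(C)C(C)(C)C)O[C@@H](n1cc(C)c(=O)n(C)c1=O)[C@@H]2O[Si](C)(C)C(C)(C)C`, in this assay gives 20000 nM
- compound 3, `Cc1cn([C@@H]2O[C@H](CO[Si](C)(C)C(C)(C)C)[C@@]3(OS(=O)(=O)C=C3NCCC(=O)O)[C@H]2O[Si](C)(C)C(C)(C)C)c(=O)n(C)c1=O`, in this assay gives 80000 nM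

Compound 3 has the highest of the three numbers, meaning the most compound is tolerated before cells are harmed. One gap is a 1.2-fold higher number from compound 1 to compound 3 (0.09 log units; within the scatter), which is no real difference, whereas the other gap is a 4.0-fold higher number from compound 2 to compound 3 (0.60 log units; beyond the scatter).

Compound 4, `Cc1cn([C@@H]2O[C@H](CO[Si](C)(C)C(C)(C)C)[C@@]3(OS(=O)(=O)C=C3NCCC(=O)OCc3ccccc3)[C@H]2O[Si](C)(C)C(C)(C)C)c(=O)n(C)c1=O`, is the next compound. It differs from compound 3 by benzyl in place of hydrogen on an oxygen next to a carbonyl group. Going by the values given here, none of the measured steps changes the same spot: the steps from compound 1 and compound 2 all alter what sits on the amine nitrogen or the chain carbon, and the one that touches the carboxy end, a 1.2-fold higher number from compound 1 to compound 3 (0.09 log units; within the scatter), stayed within the scatter. Among the compounds with values here, with no step of the same kind to lean on, the expectation for compound 4 is a step of about a 1.6-fold lower number from compound 3 to compound 4 (0.20 log units; within the scatter), most likely inside the scatter, with a lower number somewhat more likely than a higher one. Compound 4 is therefore estimated at 50000 nM, within 20000 nM to 100000 nM.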

Compound 4, minimum cytotoxic concentration: >= 400000 nM
Compound 4: a limit, no number; the forecaster's own chance of this, stated with the estimate: 10%; middle value at least 8.0-fold (0.90 log units) from the limit.
By their numbers in this assay, from the lowest: compound 2; then compounds 1 and 3 (each within the scatter of the next). At a limit, above all of these: compound 4.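

Compound 4 gives a limit, not a number, in this assay: the limit of >= 400000 nM in this assay, at which 1 of the 4 values shown sits.

Going by these compounds alone, replacing the hydrogen on this oxygen next to a carbonyl group, which turns the carboxy group into benzyloxycarbonyl, gives an at least 5.0-fold higher number from compound 3 to compound 4 (0.69 log units; beyond the scatter), so this end of the chain, untouched by the earlier steps on its own, can shift how much compound the cells tolerate. The same compound also stands clear of both other compounds, with an at least 6.1-fold higher number from compound 1 to compound 4 (0.78 log units; beyond the scatter) and an at least 20-fold higher number from compound 2 to compound 4 (1.30 log units; beyond the scatter), which makes it the best tolerated of the four.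

On these data alone, with only a limit, the full size of these steps remains unknown. As far as these compounds go, it also remains open whether a small methyl ester or an amide at this oxygen's place would match the benzyl group, or whether the aromatic ring of the benzyl group is needed.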